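A Methyl-Triazole Takes the Place of a Pyrazole

This account rests on a few compounds, and the source may have more. Where it says the series, first, only, none or still open, it means among the compounds named here.

Compound 1 `Cn1nccc1-c1ccccc1NCC1=NCCN1`: 108%
Compound 2 `Cc1nc(-c2ccccc2NCC2=NCCN2)n(C)n1`: 98%
Compound 3 `c1ccc(-c2cn[nH]c2)c(NCC2=NCCN2)c1`: 112%

These numbers come from a functional assay with Alpha-1A adrenergic receptor (Homo sapiens) as the target, read by calcium flux; a higher number here means a larger maximal response, a lower number a smaller maximal response. Compound 3 and compound 1 lie within the usual scatter of each other and cannot be told apart; compound 2 sits below compound 3 by more than the scatter. Compound 4 `Cc1n[nH]c(-c2ccccc2NCC2=NCCN2)n1` is not yet measured; the change from compound 3 is 3-methyl-1H-1,2,4-triazol-5-yl in place of 1H-pyrazol-4-yl on an aromatic carbon. Among the measured compounds shown here, the only measured step on the same aromatic carbon, a number 4 percentage points higher from compound 1 to compound 3 (within the scatter), stayed within the scatter. Compound 2, which carries a closely related methyl-bearing ring, gives 98% in this assay, so a small fall is expected for compound 4, a number 9 percentage points lower from compound 3 to compound 4 (within the scatter), still inside the scatter. Compound 4 is therefore estimated at 103%, with a range from 90% to 116%.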

Compound 4, largest response reached (reported as maximal response), in percent of the reference or control that the assay uses: 87%
Beside the measured number, compound 4's estimate is 16 percentage points above it; the whole stated range lies above it.
By their numbers in this assay, from the lowest: compound 4; then compounds 2, 1 and 3 (each within the scatter of the next, the first and the last beyond it).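

In this assay, the ring on this aromatic carbon does matter: the 3-methyl-1H-1,2,4-triazol-5-yl group gives a clear drop (a number 25 percentage points lower from compound 3 to compound 4 (beyond the scatter)) and (a number 21 percentage points lower from compound 1 to compound 4 (beyond the scatter)), unlike the earlier change of pyrazole (a number 4 percentage points higher from compound 1 to compound 3 (within the scatter)). On the triazole, hydrogen in place of methyl on an aromatic nitrogen also goes with a lower response (a number 11 percentage points lower from compound 2 to compound 4 (beyond the scatter)). Nothing available explains these falls. Still open, going by these compounds, is whether a plain triazole, without the methyl on carbon, would restore the response, and what an amine or a longer alkyl chain on the ring would do.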